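A few compounds are considered here, and "the series" means these few. Any claim that something is new, unique, unknown or untested is made for them only; others in the source may bear on it.

Working notes on the series. In a functional assay on K562 cells (Homo sapiens) for antiproliferative activity, read by MTT assay, with a stated time of 48 h (on this read-out lower numbers stand for stronger inhibition and higher numbers for weaker inhibition), compound 1 `COc1cc(CNC(=O)CCCC/C=C/C(C)C)ccc1OCCCCOc1ccc(C(N)=S)cc1` reaches only the limit of the assay, > 50000 nM. Compound 3 `COc1cc(CNC(=O)CCCC/C=C/C(C)C)ccc1OC(=O)CCC(=O)Oc1ccc(C(N)=S)cc1` likewise gives only a limit, > 50000 nM. Compound 2 `COc1cc(CNC(=O)CCCC/C=C/C(C)C)ccc1OC(=O)CCC(=O)Oc1ccc(-c2cc(=S)ss2)cc1` gives 4450 nM. Compound 2 differs from compound 3 by a group of 6 heavy atoms (3 carbon, 3 sulfur; one five-membered aromatic ring with 2 hetero atoms) in place of a group of 3 heavy atoms (1 carbon, 1 nitrogen, 1 sulfur; no ring), on an aromatic carbon; the measured step is an at least 11-fold lower number from compound 3 to compound 2 (1.05 log units; beyond the scatter), read against (the limit of > 50000 nM in this assay, at which 2 of the 3 values shown sit). Compound 4 `COc1cc(CNC(=O)CCCC/C=C/C(C)C)ccc1OCCCCOc1ccc(-c2cc(=S)ss2)cc1` has not been measured. It differs from compound 1 by a group of 6 heavy atoms (3 carbon, 3 sulfur; one five-membered aromatic ring with 2 hetero atoms) in place of a group of 3 heavy atoms (1 carbon, 1 nitrogen, 1 sulfur; no ring), on an aromatic carbon, the same change at the same place. How the core of compound 1 differs from the core of compound 3 is not broken down here. A step of comparable size is expected in this assay, estimated as an at least 8.3-fold lower number from compound 1 to compound 4 (0.92 log units; beyond the scatter), resting on compound 3 and compound 2, where the step was an at least 11-fold lower number from compound 3 to compound 2 (1.05 log units; beyond the scatter). Compound 4 is therefore estimated at 6000 nM, within 1500 nM to 25000 nM.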

Compound 4, half-maximal inhibitory concentration: > 50000 nM
Compound 4: only a limit was reported; the forecaster's own chance of this, stated with the estimate: 20%; middle value at least 8.3-fold (0.92 log units) from the limit.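

No step can be read from compound 1 to compound 4, since both values are limits: the limit of > 50000 nM in this assay, at which 3 of the 4 values shown sit. The compounds shown leave open whether the step seen on the core of compound 3 has any counterpart on the core of compound 1.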